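A few compounds are considered here, and "the series" means these few. Any claim that something is new, unique, unknown or untested is made for them only; others in the source may bear on it.

Within the data shown here, only two compounds have been measured so far in a functional assay on HeLa cells (Homo sapiens) for inhibition, read by MTT assay, with a stated time of 48 h; on this read-out lower numbers stand for stronger inhibition and higher numbers for weaker inhibition. Compound 1 (`c1ccc(C(c2c[nH]c3ccccc23)c2c[nH]c3ccccc23)cc1`) gives 21800 nM. Compound 2 (`Brc1ccc2[nH]cc(C(c3ccccc3)c3c[nH]c4ccc(Br)cc34)c2c1`) gives 900 nM, the lower of the two numbers, and the gap between them lies well beyond the usual scatter of repeated measurements. Compound 2 is therefore the stronger inhibitor of the pair, and it serves as the reference for the next comparison.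

Compound 3 (`Oc1ccc(C(c2c[nH]c3ccc(Br)cc23)c2c[nH]c3ccc(Br)cc23)cc1`) differs from compound 2 in a single place: hydroxy in place of hydrogen on an aromatic carbon. This is hydroxy in place of hydrogen on an aromatic carbon, para to a large group, so phenyl becomes 4-hydroxyphenyl. Among the measured compounds shown here, no measured pair here shows what this change does in this assay, so any forecast carries wide uncertainty. The expectation is a small weakening, an estimated 1.8-fold higher number from compound 2 to compound 3 (0.25 log units; within the scatter), about the size of the usual scatter. In this assay the estimated value for compound 3 is 1600 nM, with an expected range from 400 nM to 6000 nM.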

Compound 3, half-maximal inhibitory concentration: 4000 nM
Compound 3: middle estimate off by 2.5-fold (0.40 log units), on the low side; low and high end bracket the measured number.
By their numbers in this assay, from the lowest: compound 2; then compound 3; then compound 1.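

In this assay, placing hydroxy on an aromatic carbon para to a large group gives a 4.4-fold higher number from compound 2 to compound 3 (0.65 log units; beyond the scatter), so this position is not indifferent to the change. Going from phenyl to 4-hydroxyphenyl weakens inhibition, and this step lies beyond the usual scatter of repeated measurements. Among these compounds, this is the first direct reading of any change at this ring, and it gives both a direction and a size, though only for one pair built on the core of compound 2, and compound 3 still retains measurable inhibition at 4000 nM. No measurement at hand gives a reason for this weakening.

As far as these compounds go, it remains open whether the loss is specific to hydroxy or would also appear with a methoxy group, an amine or a carboxylic acid on the same carbon, and a fluorine atom there would test whether a much smaller replacement behaves differently. It is also unknown whether hydroxy would have the same effect on the core of compound 1, which carries no bromine, or at other carbons of this ring.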